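The source may report more compounds than this note shows. Statements on the series, on what has been measured and on what is new or still open speak of the compounds shown alone.

Compound 1 `COc1cccc(N2CCN(CC(=O)N3CCN(c4nnc(-c5ccccc5)c(-c5ccccc5)n4)CC3)CC2)c1`: > 910000 nM
Compound 2 `COc1cccc(N2CCN(CC(=O)N3CCN(c4nnc(-c5ccc(C)cc5)c(-c5ccc(C)cc5)n4)CC3)CC2)c1`: 867000 nM
Compound 3 `COc1ccc(-c2nnc(N3CCN(C(=O)CN4CCN(c5ccccc5)CC4)CC3)nc2-c2ccc(OC)cc2)cc1`: > 863000 nM

Three compounds built on a shared core were tested in a functional assay on MCF7 cells (Homo sapiens) for cytotoxicity, read by MTT assay, with a stated time of 24 h; on this read-out lower numbers stand for stronger inhibition and higher numbers for weaker inhibition. For compound 1 the result is a limit of the assay, > 910000 nM. Compound 2 gives 867000 nM. For compound 3 the read-out is likewise only a limit, > 863000 nM, so no number places it against the other two; all three results sit at the edge of what this assay resolves, as the lines the limit of > 863000 nM in this assay, at which 1 of the 3 values shown sits, and the limit of > 910000 nM in this assay, at which 1 of the 3 values shown sits, show.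

Compound 4 `COc1ccc(-c2nnc(N3CCN(C(=O)CN4CCN(c5cccc(OC)c5)CC4)CC3)nc2-c2ccc(OC)cc2)cc1` differs from compound 3 by methoxy in place of hydrogen on an aromatic carbon. Compound 1 already carries the same 3-methoxyphenyl group and was reported in this assay as > 910000 nM. The step from compound 3 to compound 4 in this assay is therefore expected to be a step that the limit leaves unreadable from compound 3 to compound 4, none beyond the scatter. Compound 4 is estimated at 900000 nM, between 500000 nM and 2000000 nM, most likely again returned only as a limit.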

Compound 4, half-maximal inhibitory concentration: > 821000 nM
Compound 4 gave a limit, no number; the forecaster's own chance of this, stated with the estimate: 80%; the middle value does not contradict the limit.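

Compound 3 and compound 4 both stand only as limits in this assay, and no step can be read between them. The compounds shown leave open whether methoxy in place of hydrogen on this aromatic carbon changes cytotoxicity at all.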